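A few compounds are considered here, and "the series" means these few. Any claim that something is new, unique, unknown or untested is made for them only; others in the source may bear on it.

Of the compounds shown here, two built on the same core have been tested in an ADME assay on HEL cells (Homo sapiens), read by cell counting, with a stated time of 3 days; on this read-out lower numbers stand for higher toxicity in this test and higher numbers for lower toxicity in this test. Compound 1 `CCCc1ccc(C#CC#Cc2cn([C@H]3C[C@H](O)[C@@H](CO)O3)c(=O)[nH]c2=O)cc1` gives 52000 nM. Compound 2 `Nc1cccc(C#CC#Cc2cn([C@H]3C[C@H](O)[C@@H](CO)O3)c(=O)[nH]c2=O)c1` reaches only the limit of the assay, giving > 100000 nM in this assay, so no exact number is known for it. The measured step of an at least 1.9-fold higher number from compound 1 to compound 2 (0.28 log units; that floor lies within the scatter) is therefore only a floor, and it rests on (the limit of > 100000 nM in this assay, at which 1 of the 2 values shown sits). Compound 3 `Cc1cc(C#CC#Cc2cn([C@H]3C[C@H](O)[C@@H](CO)O3)c(=O)[nH]c2=O)ccc1F` has not yet been measured; it differs from compound 2 by 4-fluoro-3-methylphenyl in place of 3-aminophenyl on a triple-bonded carbon. Among the compounds with values here, the only measured step that bears on this change is the one from compound 1 to compound 2, whose floor lies within the usual scatter, so no movement beyond the scatter is expected in this assay. Compound 3 is therefore estimated at 70000 nM, with a likely range from 30000 nM to 150000 nM, which corresponds to an expected step of an at least 1.4-fold lower number from compound 2 to compound 3 (0.15 log units; that floor lies within the scatter).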

Compound 3, half-maximal cytotoxic concentration: 45000 nM
The estimate for compound 3 lay 1.6-fold (0.19 log units) above the measured number, and the stated range covers the measured number.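

In this assay, within the data shown here, this change on the triple-bonded carbon gives an at least 2.2-fold lower number from compound 2 to compound 3 (0.34 log units; beyond the scatter), the first step that goes beyond the scatter, and so the group at this place can shift the read-out towards higher toxicity in this test. Swapping one group without an amine for another does not do this, as the comparison of the other two compounds gives a 1.2-fold lower number from compound 1 to compound 3 (0.06 log units; within the scatter), so 4-fluoro-3-methylphenyl and 4-propylphenyl cannot be told apart here. For compound 2, > 100000 nM is a limit and not a number, so the step away from it is only a floor: the limit of > 100000 nM in this assay, at which 1 of the 3 values shown sits.

As far as these compounds go, whether the amine itself sets compound 2 apart remains open. A hydroxyl or a carboxylic acid on the phenyl ring could show whether other groups give a similarly high number.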